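Aminoacyl group in place of the phenylpropyl chain

The source may hold more compounds than are shown below. What is called first, only, known or untested is meant among the compounds shown, and "the series" means these compounds.

Within the data shown here, compound 3 `COc1ccc(NC(=O)[C@@H]2Cc3ccc(OCC(=O)NO)cc3CN2C(=O)CCCc2ccccc2)cc1` gives 114 nM in an assay on isolated protein for inhibition of histone deacetylase 8 (Homo sapiens), read by fluorescence, with a stated time of 30 min (on this read-out lower numbers stand for stronger inhibition and higher numbers for weaker inhibition), and holds the lowest of the three numbers measured so far. Compound 2 `COc1ccc(NC(=O)[C@@H]2Cc3ccc(OCC(=O)NO)cc3CN2C(=O)CNC(=O)OC(C)(C)C)cc1` gives 514 nM in this assay, and compound 1 `O=C(COc1ccc2c(c1)CN(C(=O)CCc1ccccc1)[C@H](C(=O)Nc1ccccc1)C2)NO` gives 759 nM; both lie beyond the scatter above compound 3. Among the measured compounds shown here, the only single-point step measured, a 4.5-fold lower number from compound 2 to compound 3 (0.65 log units; beyond the scatter), shows that a chain carrying a phenyl ring on the carbonyl bound to the ring nitrogen reads lower than a chain carrying a (tert-butoxycarbonyl)amino group.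

Compound 4 `COc1ccc(NC(=O)[C@@H]2Cc3ccc(OCC(=O)NO)cc3CN2C(=O)[C@@H](N)C(C)C)cc1` differs from compound 3 by 1-amino-2-methylpropyl in place of 3-phenylpropyl on a carbonyl carbon. For the measured compounds named here, no measured pair covers this exact exchange. The nearest guide is the same step read backwards: taking the phenyl-bearing chain away in favour of a nitrogen-bearing chain cost a modest amount there, and the change to compound 4 also removes the aromatic ring while adding a donor and an acceptor, though the group entering is shorter and carries a free amine rather than a carbamate. A modest rise in the number, a 3.5-fold higher number from compound 3 to compound 4 (0.55 log units; beyond the scatter), is therefore expected rather than none beyond the scatter. Compound 4 is estimated at 400 nM, with a range of 150 nM to 1200 nM.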

Compound 4, half-maximal inhibitory concentration: 1020 nM
For compound 4 the middle estimate is 2.6-fold (0.41 log units) below the measured one; the range from low to high includes it.
By their numbers in this assay, from the lowest: compound 3; then compounds 2, 1 and 4 (each within the scatter of the next).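

In this assay, the exchange of 3-phenylpropyl for 1-amino-2-methylpropyl on the carbonyl carbon bound to the amide-type nitrogen in a ring gives an 8.9-fold higher number from compound 3 to compound 4 (0.95 log units; beyond the scatter), a second case in which a group without the phenyl ring and carrying nitrogen reads higher than a phenyl-bearing chain at this position. The step of a 2.0-fold higher number from compound 2 to compound 4 (0.30 log units; within the scatter) places the two nitrogen-bearing groups, 1-amino-2-methylpropyl and ((tert-butoxycarbonyl)amino)methyl, within the scatter of each other, so these compounds do not separate the free amine from the carbamate despite their different size. Among compounds 2, 3 and 4, then, only compound 3 stands apart, and nothing available here gives a reason for that gap.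

Still open, going by these compounds, is whether the lower number of compound 3 goes with the phenyl ring itself or with the length of the chain, a question that a plain pentyl chain on the same carbonyl carbon would address. Also open, on these data alone, is how the 1-amino-2-methylpropyl result would shift with an acetamide or a carboxylic acid in place of the free amine.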